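A few compounds are considered here, and "the series" means these few. Any claim that something is new, unique, unknown or untested is made for them only; others in the source may bear on it.

Measured in a functional assay on HCT-15 cells (Homo sapiens) for cytotoxicity, read by MTT assay, with a stated time of 2 days; on this read-out higher numbers stand for weaker inhibition and lower numbers for stronger inhibition:
compound 1 `Cc1cccc(-c2nc3cc(C)ccc3c(=O)[nH]2)c1`: 21100 nM
compound 2 `CN(C)c1ccc2nc(-c3cccc4ccccc34)[nH]c(=O)c2c1`: 460 nM
compound 3 `Cc1ccc2c(=O)[nH]c(-c3ccccc3C)nc2c1`: 11900 nM

In this assay, compound 1, at 21100 nM, lies within the scatter of compound 3, at 11900 nM, so the two cannot be told apart. Compound 2, at 460 nM, has a much lower number, well beyond the scatter from compound 1.

The next compound to be tested is compound 4 `Cc1ccc2c(=O)[nH]c(-c3cccc(F)c3)nc2c1`, which keeps the core of compound 1 and changes a single group: fluoro in place of methyl on an aromatic carbon. This is fluoro in place of methyl on an aromatic carbon, on a six-membered aromatic ring of carbon only, meta to a large group. Among the measured compounds shown here, no two measured compounds differ in just one place, so the data offer no direct precedent for this swap. For the measured compounds named here, the only guide is indirect: compound 3, at 11900 nM, also carries a methyl group on that ring and still sits within the scatter of compound 1. On that limited basis, no change beyond the scatter is expected. The estimated step is a 1.4-fold lower number from compound 1 to compound 4 (0.15 log units; within the scatter). For compound 4 the expected value is 15000 nM, with an estimated range from 6000 nM to 40000 nM.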

Compound 4, half-maximal inhibitory concentration: 14400 nM
The estimate for compound 4 lay 1.0-fold (0.02 log units) above the measured number, and the stated range covers the measured number.
By their numbers in this assay, from the lowest: compound 2; then compounds 3, 4 and 1 (each within the scatter of the next).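

In this assay, among the compounds shown here, the pair formed by compound 1 and compound 4 gives the first direct reading of a single swap on the shared core, which none of the earlier compounds could provide (a 1.5-fold lower number from compound 1 to compound 4 (0.17 log units; within the scatter)). At this place, on a six-membered aromatic ring of carbon only and meta to a large group, fluoro in place of methyl leaves the two compounds impossible to tell apart, so the methyl group of compound 1 is not needed there to hold its level in this assay. Nothing measured here bears on why the two compounds read alike.

This is one swap at one place, with two small groups that each count a single heavy atom, so it shows only that these two read alike. On these data alone, whether a methoxy group, a nitrile or a carboxylic acid at the same place would also read alike stays open, as does whether fluoro in place of methyl would give the same reading on a core carrying a different group elsewhere.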